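Resolving the racemate: compound 4 as the single R enantiomer

A few compounds are considered here, and "the series" means these few. Any claim that something is new, unique, unknown or untested is made for them only; others in the source may bear on it.

Compound 1 `CC1CCC(Nc2nc(C(F)(F)F)ccc2CNC(=O)C(C)c2ccc(NS(C)(=O)=O)c(F)c2)CC1`: 1130 nM
Compound 2 `CC(C(=O)NCc1ccc(C(F)(F)F)nc1N(C)c1ccccc1)c1ccc(NS(C)(=O)=O)c(F)c1`: 57.4 nM
Compound 3 `CC(C(=O)NCc1ccc(C(F)(F)F)nc1N1CCC(c2ccccc2)CC1)c1ccc(NS(C)(=O)=O)c(F)c1`: 25 nM

In a functional assay on CHO-K1 cells for antagonist activity at transient receptor potential cation channel subfamily V member 1 (Homo sapiens), read by FLIPR (a lower number here means a stronger inhibitor, a higher number a weaker inhibitor), compound 3 gives the lowest number of the three; compound 2 sits nearest, with a 2.3-fold lower number from compound 2 to compound 3 (0.36 log units; beyond the scatter) separating them, and compound 1 is furthest, with a 45-fold lower number from compound 1 to compound 3 (1.66 log units; beyond the scatter). Compound 4 `C[C@@H](C(=O)NCc1ccc(C(F)(F)F)nc1N1CCC(c2ccccc2)CC1)c1ccc(NS(C)(=O)=O)c(F)c1` keeps every atom and bond of compound 3: the two compounds have the same atoms and bonds; at least one stereo element is drawn with a configuration in one of them and without one in the other: 1 of 1 stereo elements differ; a stereocentre at a saturated chain carbon is drawn without a configuration in compound 3 and R in compound 4. Within the data shown here, none of the measured steps concerns a stereocentre; all three change the group on the aromatic carbon, for example a 20-fold lower number from compound 1 to compound 2 (1.29 log units; beyond the scatter). A single enantiomer drawn from a mixture can only be about as strong as the mixture, or weaker if it is the less active form. For compound 4 in this assay the expected value is 18 nM, within 7 nM to 80 nM, meaning an expected step of a 1.4-fold lower number from compound 3 to compound 4 (0.14 log units; within the scatter).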

Compound 4, half-maximal inhibitory concentration: 2350 nM
Estimate against measurement, compound 4: 130-fold (2.12 log units) below; measured number outside the range, above it.
By their numbers in this assay, from the lowest: compound 3; then compound 2; then compound 1; then compound 4.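

In this assay, nothing but the configuration separates these two compounds, yet the result is a 94-fold higher number from compound 3 to compound 4 (1.97 log units; beyond the scatter). The earlier steps shown here all changed the group on the aromatic carbon, whereas this one shows that the stereocentre at the saturated chain carbon matters strongly in its own right. The R form can therefore account for little of the activity of compound 3, and the only structural difference on record is this: the fact that one of compounds 3 and 4 is drawn with a defined configuration and the other without, at the place where they differ

From the compounds shown here alone, the S enantiomer remains open, as does whether the same preference holds with methyl(phenyl)amino in place of 4-phenylpiperidin-1-yl. An ethyl group at the stereocentre is also untested among the compounds shown.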